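A second carbon on the ring amine substituent

The source may hold more compounds than are shown below. What is called first, only, known or untested is meant among the compounds shown, and "the series" means these compounds.

Compound 1 `CN1CCC(n2cc(S(=O)(=O)c3cccc(Cl)c3)c3cccnc32)C1` and compound 2 `CCN1CCC(n2cc(S(=O)(=O)c3cccc(Cl)c3)c3cccnc32)C1` share one core. In an assay on HeLa cells for displacement of a labelled ligand from 5-hydroxytryptamine receptor 6 (Homo sapiens) (on this read-out lower numbers stand for stronger inhibition and higher numbers for weaker inhibition), compound 1 gives 1.5 nM, while compound 2 gives 3.3 nM. The change between them, (methyl in place of hydrogen on a saturated chain carbon bound to an amine nitrogen in a ring), produced a 2.2-fold higher number from compound 1 to compound 2 (0.34 log units; beyond the scatter). Compound 3 `CCN1CCCC(n2cc(S(=O)(=O)c3cccc(F)c3)c3cccnc32)C1` gives 4.4 nM in this assay; how its core differs from the core of compound 1 is not broken down here. Compound 4 `CC(C)N1CCCC(n2cc(S(=O)(=O)c3cccc(F)c3)c3cccnc32)C1` has not been measured; it differs from compound 3 by methyl in place of hydrogen on a saturated chain carbon bound to an amine nitrogen in a ring and a saturated chain carbon. This is the same kind of change as from compound 1 to compound 2, but here the place is a saturated chain carbon bound to an amine nitrogen in a ring and a saturated chain carbon. A similar modest weakening is expected, a 1.8-fold higher number from compound 3 to compound 4 (0.26 log units; within the scatter), resting on a 2.2-fold higher number from compound 1 to compound 2 (0.34 log units; beyond the scatter). Compound 4 is therefore estimated at 8 nM, expected between 3 nM and 20 nM.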

Compound 4, inhibition constant: 3.4 nM
Estimate against measurement, compound 4: 2.4-fold (0.37 log units) above, within the range that was stated.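

Changing 1-ethylpiperidin-3-yl to 1-isopropylpiperidin-3-yl gives a 1.3-fold lower number from compound 3 to compound 4 (0.11 log units; within the scatter), so in this assay compound 3 and compound 4 cannot be told apart. The weakening seen when the same methyl was added on the core of compound 1 therefore did not carry over to this core, and the change cannot be assumed to have one fixed effect in this series: the same change on two cores in this assay, a 2.2-fold higher number (0.34 log units; beyond the scatter) from compound 1 to compound 2 and a 1.3-fold lower number (0.11 log units; within the scatter) from compound 3 to compound 4, 2.8-fold (0.45 log units) apart, beyond the scatter of two such steps Two pairs do not show which difference between the cores matters, nor how the change would behave on any other core.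

Going by these compounds, it remains open how a longer chain, such as propyl, or a tert-butyl group would read in that place. Also open, on these data alone, is how isopropyl itself would read on the core of compound 1.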